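Indole acrylonitrile series: removing the N-benzyl group

The compounds below may be only part of what the source reports. "The series", "measured", "known", "first", "only" and "open" are said of these compounds alone.

Compound 2 `COc1ccc(Cn2cc(/C=C(\C#N)C(=O)c3c[nH]c4cc(OC)ccc34)c3ccccc32)cc1` gives 28900 nM in a functional assay on A549 cells (Homo sapiens) for cytotoxicity, read by WST assay, with a stated time of 48 h (a higher number here means a weaker inhibitor, a lower number a stronger inhibitor), the highest of the three numbers; compound 1 `COc1ccc2[nH]cc(/C=C(\C#N)C(=O)c3c[nH]c4ccc(OC)cc34)c2c1` gives 24500 nM, within the scatter of compound 2, while compound 3 `COc1ccc2[nH]cc(/C=C(\C#N)C(=O)c3c[nH]c4ccccc34)c2c1` gives 13700 nM, beyond it. Among the compounds with values here, the only single-point step recorded, a 1.8-fold lower number from compound 1 to compound 3 (0.25 log units; within the scatter), concerns a methoxy on an aromatic carbon and lies within the scatter. Compound 4 `COc1ccc2c(C(=O)/C(C#N)=C/c3c[nH]c4ccccc34)c[nH]c2c1` differs from compound 2 by hydrogen in place of 4-methoxybenzyl on an aromatic nitrogen. Within the data shown here, no measured pair isolates this change, so the expectation rests on the narrow spread of all three values. The step of a 1.4-fold lower number from compound 2 to compound 4 (0.16 log units; within the scatter) is expected to stay within the scatter. Compound 4 is therefore estimated at 20000 nM, with a range from 8000 nM to 50000 nM.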

Compound 4, half-maximal inhibitory concentration: 7500 nM
Compound 4: middle estimate off by 2.7-fold (0.43 log units), on the high side; measured number outside the range, below it.
By their numbers in this assay, from the lowest: compounds 4, 3, 1 and 2 (each within the scatter of the next, the first and the last beyond it).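

Within the data shown here, replacing 4-methoxybenzyl with hydrogen on the aromatic nitrogen gives a 3.9-fold lower number from compound 2 to compound 4 (0.59 log units; beyond the scatter) in this assay and is the first single-place step beyond the scatter. Among these compounds, the earlier methoxy step, a 1.8-fold lower number from compound 1 to compound 3 (0.25 log units; within the scatter) by contrast, stayed within it, so this nitrogen is the first position where a change clearly moves the number, though only this one pair shows it. No measurement on hand accounts for the step.

As far as these compounds go, whether a methyl group or an aminoethyl chain on this nitrogen falls nearer compound 2 or compound 4 remains open. Also open, from the compounds shown here alone, is whether the step recurs with the methoxy placed elsewhere on the core.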